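This account rests on a few compounds, and the source may have more. Where it says the series, first, only, none or still open, it means among the compounds named here.

Two compounds frame the series in a physicochemical assay for solubility, in phosphate buffer, with a stated time of 18 h; a lower number here means a less soluble compound, a higher number a more soluble compound. Compound 1 (`CC(C)(C)c1nc(-c2ccc[nH]2)c2cc(C(N)=O)c(N)nc2n1`) gives 130000 nM. Compound 2 (`CC(C)(C)c1nc(-c2nccs2)c2c(N)c(C#N)c(N)nc2n1`) gives < 1500 nM, which is a limit of the assay and not a number. The evidence on where it stands is the limit of < 1500 nM in this assay, at which 1 of the 2 values shown sits.

Compound 3 (`CC(C)(C)c1nc(-c2ncc[nH]2)c2c(N)c(C#N)c(N)nc2n1`) takes compound 2 and puts 1H-imidazol-2-yl in place of 1,3-thiazol-2-yl on an aromatic carbon. Within the data shown here, no measured pair isolates this change, so any figure for it is an expectation only. A moderate rise in this assay is expected, with a real chance that compound 3 also returns only a limit. Compound 1, at 130000 nM, shows that high numbers occur in the series, although it differs from compound 3 in more than one place. The expected change, an at least 4.0-fold higher number from compound 2 to compound 3 (0.60 log units; beyond the scatter), is therefore upward and of uncertain size. For compound 3 the estimated value in this assay is 6000 nM, with an expected range of 1200 nM to 35000 nM.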

Compound 3, solubility: < 1000 nM
Compound 3: no number, only a limit (the forecaster's own chance of this, stated with the estimate: 30%); middle value at least 6.0-fold (0.77 log units) away from the limit.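

Compound 2 and compound 3 each return only a limit of the assay and not a number, so the exchange of 1,3-thiazol-2-yl for 1H-imidazol-2-yl cannot be read as a step. The compounds shown leave open what size, and even what direction, this exchange has in this assay.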